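Amino chalcone series: fluorophenyl for dimethoxyphenyl

The source may report more compounds than this note shows. Statements on the series, on what has been measured and on what is new or still open speak of the compounds shown alone.

Compound 1 `COc1ccc(-c2cc(C(=O)/C=C/c3cc(OC)c(OC)c(OC)c3)ccc2N)cc1OC` gives 4330 nM in a functional assay on CNE-2 cells (Homo sapiens) for cytotoxicity, read by sulforhodamine B assay, with a stated time of 48 h; a lower number here means a stronger inhibitor, a higher number a weaker inhibitor. Compound 2 `COc1ccc(-c2cc(C(=O)/C=C/c3cccc(OC)c3OC)ccc2N)cc1OC` carries the same amino-bearing core as compound 1, but the difference between the two cores is not broken down here; in this assay compound 2 gives 6600 nM. Compound 3 `COc1cc(/C=C/C(=O)c2ccc(N)c(-c3ccc(F)cc3)c2)cc(OC)c1OC` gives 4600 nM in this assay. From compound 1 to compound 3 the change is 4-fluorophenyl in place of 3,4-dimethoxyphenyl on an aromatic carbon, and it made a step of a 1.1-fold higher number from compound 1 to compound 3 (0.03 log units; within the scatter). Compound 4 `COc1cccc(/C=C/C(=O)c2ccc(N)c(-c3ccc(F)cc3)c2)c1OC` is not yet measured; it differs from compound 2 by 4-fluorophenyl in place of 3,4-dimethoxyphenyl on an aromatic carbon, the same change at the same place. Beside a 1.1-fold higher number from compound 1 to compound 3 (0.03 log units; within the scatter), the expected step is a 1.1-fold higher number from compound 2 to compound 4 (0.04 log units; within the scatter), resting on the observation that this change left compound 1 and compound 3 within the scatter of each other. Compound 4 is therefore estimated at 7200 nM in this assay, with a likely range from 3500 nM to 15000 nM.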

Compound 4, half-maximal inhibitory concentration: 11300 nM
For compound 4 the middle estimate is 1.6-fold (0.20 log units) below the measured one, and the stated range covers the measured number.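

In this assay, the second case of 4-fluorophenyl in place of 3,4-dimethoxyphenyl gives a 1.7-fold higher number from compound 2 to compound 4 (0.23 log units; within the scatter), and the two cases do not differ beyond the scatter: the same change on two cores in this assay, a 1.1-fold higher number (0.03 log units; within the scatter) from compound 1 to compound 3 and a 1.7-fold higher number (0.23 log units; within the scatter) from compound 2 to compound 4, 1.6-fold (0.21 log units) apart, within the scatter of two such steps. On the two cores shown, the change therefore carries across with no detectable difference, and neither step separates the two aryl groups in this read-out. Two pairs, both within the scatter, do not show that the change is neutral on other cores, and they give no reason for the result.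

The compounds shown leave open whether a pyridine ring or a morpholine in place of these aryl groups would give a step beyond the scatter. They also leave open what a carboxylic acid in place of the amino group would do.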